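This account rests on a few compounds, and the source may have more. Where it says the series, first, only, none or still open, it means among the compounds named here.

Compound 1 `COc1cc(C2=NN(C(C)=O)C(c3cc(Cl)cc(Cl)c3)O2)cc(OC)c1OC`: 93.9%
Compound 2 `COc1ccc(OC)c(C2OC(c3cc(OC)c(OC)c(OC)c3)=NN2C(C)=O)c1`: 43.2%
Compound 3 `COc1cc(C2=NN(C(C)=O)C(c3ccc(Cl)c(Cl)c3)O2)cc(OC)c1OC`: 26.1%

In a functional assay on PC-3 cells (Homo sapiens) for antiproliferative activity, read by MTT assay, tested at 5 uM (on this read-out higher numbers stand for a stronger effect at the one concentration tested and lower numbers for a weaker effect), compound 3 gives 26.1%, the lowest of the three numbers; the nearest is compound 2 at 43.2%, and the step of a number 67.8 percentage points lower from compound 1 to compound 3 (beyond the scatter) shows how far compound 3 sits from compound 1. Compound 4 `COc1cc(C2=NN(C(C)=O)C(c3ccc(Cl)c([N+](=O)[O-])c3)O2)cc(OC)c1OC` differs from compound 3 by nitro in place of chloro on an aromatic carbon. Among the measured compounds shown here, no measured step swaps chloro for nitro, so none bears directly on this change. The steps of a number 67.8 percentage points lower from compound 1 to compound 3 (beyond the scatter) and a number 17.1 percentage points lower from compound 2 to compound 3 (beyond the scatter) do show that altering the pendant aryl group can move the read-out strongly. For the measured compounds named here, with no direct precedent, only a loosely bounded expectation is possible: compound 4 is estimated at 35% (range 8% to 70%), which would mean an expected step of a number 8.9 percentage points higher from compound 3 to compound 4 (within the scatter).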

Compound 4, a percentage reported as inhibition, at one concentration (the size of the read-out at that concentration, not a potency): 61.4%
Compound 4: middle estimate off by 26.4 percentage points, on the low side; measured number inside the range.
By their numbers in this assay, from the lowest: compound 3; then compound 2; then compound 4; then compound 1.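

In this assay nitro in place of chloro on this aromatic carbon gives a number 35.3 percentage points higher from compound 3 to compound 4 (beyond the scatter) and so shows that one group at this position, with the rest of the molecule unchanged, can move the read-out strongly. The step is a number 18.2 percentage points higher from compound 2 to compound 4 (beyond the scatter) when 4-chloro-3-nitrophenyl replaces 2,5-dimethoxyphenyl, but a number 32.5 percentage points lower from compound 1 to compound 4 (beyond the scatter) when it replaces 3,5-dichlorophenyl, which places this aryl group in the middle of the four. No available evidence explains these differences. Going by these compounds, whether an amine or a carboxylic acid on this carbon would raise or lower the read-out remains open.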